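The source may hold more compounds than are shown below. What is called first, only, known or untested is meant among the compounds shown, and "the series" means these compounds.

Measured so far in a functional assay, with a stated time of 30 min; a higher number here means a weaker inhibitor, a lower number a stronger inhibitor
Compound 1 `CCCCCCOc1cc(OC)c(Br)cc1C(C)=O` gives 42400000 nM
Compound 2 `CCCCCCCCCCCCOc1cc(OC)c(Br)cc1C(C)=O` gives 29500000 nM

Compound 2 at 29500000 nM cannot be told apart from compound 1 on these numbers. Among the measured compounds shown here, the one measured step is a 1.4-fold lower number from compound 1 to compound 2 (0.16 log units; within the scatter) and it came with hexyl in place of hydrogen on a saturated chain carbon, six bonds along the chain from an oxygen on an aromatic ring.

Compound 3 (`CCCCCCCCCCCCCCOc1cc(OC)c(Br)cc1C(C)=O`) carries the chain further, and the change from compound 2 is ethyl in place of hydrogen on a saturated chain carbon, ten or more bonds along the chain from an oxygen on an aromatic ring on the otherwise shared core. This is a change of the same kind as the measured one but smaller, with ethyl entering where that step brought in hexyl. For the measured compounds named here, only that single step bears on it, and it gives no direction that can be relied on. No step beyond the scatter is therefore expected in this assay for this change. The expected step is a 1.1-fold lower number from compound 2 to compound 3 (0.04 log units; within the scatter) and it is estimated to stay within the scatter. For compound 3 the estimated value is 27000000 nM with an expected range from 12000000 nM to 60000000 nM for repeated measurements.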

Compound 3, half-maximal inhibitory concentration: 16100000 nM
Estimate against measurement, compound 3: 1.7-fold (0.22 log units) above; low and high end bracket the measured number.
By their numbers in this assay, from the lowest: compounds 3, 2 and 1 (each within the scatter of the next, the first and the last beyond it).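

In this assay, ethyl in place of hydrogen on a saturated chain carbon, ten or more bonds along the chain from an oxygen on an aromatic ring, gives a 1.8-fold lower number from compound 2 to compound 3 (0.26 log units; within the scatter), so this change on its own cannot be told apart from repeat measurement. Taken as a single change, the whole extension of the chain gives a 2.6-fold lower number from compound 1 to compound 3 (0.42 log units; beyond the scatter); this is the only step in the series to clear the scatter, it is modest, and compound 2 cannot be separated from either of the other two compounds. No supporting measurement is available to explain this step.

From the compounds shown here alone, whether a longer chain would extend this modest separation or leave the numbers unchanged remains open, as does the outcome of placing an amine or a carboxylic acid on the chain. Also open, going by these compounds, is how much the bromine and the methoxy group on the shared core contribute, as both are common to all three compounds.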